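This account rests on a few compounds, and the source may have more. Where it says the series, first, only, none or still open, it means among the compounds named here.

Working notes on the sulfonyl-aryl series

Three compounds sharing one core have been run in a functional assay on HEK293 cells for inhibition of 5-hydroxytryptamine receptor 6 (Homo sapiens), read by calcium flux and cAMP accumulation, with a stated time of 10 min; on this read-out lower numbers stand for stronger inhibition and higher numbers for weaker inhibition. Compound 1 `CN(C)/C=N/N=C/c1cn(S(=O)(=O)c2ccccc2)c2cccc([N+](=O)[O-])c12` gives 1830 nM. Compound 2 `CN(C)/C=N/N=C/c1cn(S(=O)(=O)c2ccc(F)cc2)c2cccc([N+](=O)[O-])c12` gives 4970 nM, and compound 3 `COc1ccc(S(=O)(=O)n2cc(/C=N/N=C/N(C)C)c3c([N+](=O)[O-])cccc32)cc1` gives 740 nM. Compound 3 stands lowest of the three, with compound 1 nearest and compound 2 furthest. The two steps from compound 1 were a 2.7-fold higher number from compound 1 to compound 2 (0.43 log units; beyond the scatter) and a 2.5-fold lower number from compound 1 to compound 3 (0.39 log units; beyond the scatter); between the two substituted analogues the step was a 6.7-fold lower number from compound 2 to compound 3 (0.83 log units; beyond the scatter).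

The next compound, compound 4 `CN(C)/C=N/N=C/c1cn(S(=O)(=O)c2ccc3ccccc3c2)c2cccc([N+](=O)[O-])c12`, differs from compound 3 by naphthalen-2-yl in place of 4-methoxyphenyl on a sulfonyl sulfur. Among the measured compounds shown here, none of the measured steps exchanges one aryl group on the sulfonyl sulfur for another ring system; the measured steps only swap a single substituent on the same phenyl ring. For the measured compounds named here, the nearest guide is that removing the methoxy gave the step from compound 3 back to compound 1, so losing that group in compound 4 is expected to cost something, while the second fused ring has no precedent here. On balance, compound 4 is expected to sit somewhat above compound 3, with a 2.0-fold higher number from compound 3 to compound 4 (0.31 log units; beyond the scatter), and a wide range. The estimate for compound 4 in this assay is 1500 nM, between 400 nM and 6000 nM.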

Compound 4, half-maximal inhibitory concentration: 2530 nM
The estimate for compound 4 lay 1.7-fold (0.23 log units) below the measured number, within the range that was stated.
By their numbers in this assay, from the lowest: compound 3; then compounds 1, 4 and 2 (each within the scatter of the next, the first and the last beyond it).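

In this assay the exchange of a single substituted phenyl ring for a fused ring system on the sulfonyl sulfur gives a 3.4-fold higher number from compound 3 to compound 4 (0.53 log units; beyond the scatter), so the lowest number in the series stays with the 4-methoxyphenyl group and is not carried over to naphthalen-2-yl. Against the other two aryl groups the same ring system brings no separation, with a 1.4-fold higher number from compound 1 to compound 4 (0.14 log units; within the scatter) and a 2.0-fold lower number from compound 2 to compound 4 (0.29 log units; within the scatter), even though compound 1 and compound 2 stand apart beyond the scatter; compound 4 therefore cannot be ordered against either of them, and the second fused ring on its own shows no clear gain or loss relative to phenyl or 4-fluorophenyl. No measurement at hand accounts for any of these steps.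

On these data alone, whether the oxygen of the methoxy group is what sets compound 3 apart remains open, and a hydroxy, an ethoxy or a dimethylamino group on the phenyl ring would be needed to test it. Also open, as far as these compounds go, is how a saturated ring such as cyclohexyl, or a nitrogen-containing aromatic ring such as pyridinyl, would behave on the sulfonyl sulfur.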